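The source may report more compounds than this note shows. Statements on the series, on what has been measured and on what is new or still open speak of the compounds shown alone.

Three compounds share one core and differ only on an aromatic carbon of the group joined to the saturated chain carbon bound to an amide-type nitrogen in a ring. Compound 1 `C=C(Br)C(=O)Nc1ccc(/C=C2\SC(=O)N(Cc3cccc(F)c3)C2=O)cc1` carries fluoro on that aromatic carbon, compound 2 `C=C(Br)C(=O)Nc1ccc(/C=C2\SC(=O)N(Cc3cccc(Cl)c3)C2=O)cc1` carries chloro, and compound 3 `C=C(Br)C(=O)Nc1ccc(/C=C2\SC(=O)N(Cc3ccccc3)C2=O)cc1` carries hydrogen. In a functional assay on FM3A cells (Mus musculus) for cytotoxicity, read by cell counting, with a stated time of 2 days (on this read-out higher numbers stand for weaker inhibition and lower numbers for stronger inhibition), compound 1 gives 4000 nM, compound 2 gives 6100 nM and compound 3 gives 3000 nM. Compound 3 shows the lowest of the three numbers, though one step toward it, a 1.3-fold lower number from compound 1 to compound 3 (0.12 log units; within the scatter), lies within the scatter, while the other, a 2.0-fold lower number from compound 2 to compound 3 (0.31 log units; beyond the scatter), is a modest step beyond it. The halogen swap itself, a 1.5-fold higher number from compound 1 to compound 2 (0.18 log units; within the scatter), is within the scatter.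

Compound 4 `C=C(Br)C(=O)Nc1ccc(/C=C2\SC(=O)N(CC)C2=O)cc1` makes a change of a different kind: methyl in place of phenyl on a saturated chain carbon bound to an amide-type nitrogen in a ring. Cut one bond further out, this reads benzyl to ethyl. Among the compounds with values here, none of the measured steps touches this part of the molecule; all three concern a single aromatic carbon and are small. There is therefore no direct guide, and the expected step in this assay is a 1.5-fold higher number from compound 3 to compound 4 (0.18 log units; within the scatter), with a wide range on either side. Compound 4 is estimated at 4500 nM, expected to fall between 1500 nM and 15000 nM.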

Compound 4, half-maximal inhibitory concentration: 2300 nM
Compound 4: middle estimate off by 2.0-fold (0.29 log units), on the high side; low and high end bracket the measured number.
By their numbers in this assay, from the lowest: compounds 4, 3, 1 and 2 (each within the scatter of the next, the first and the last beyond it).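

Swapping the benzyl group for the much smaller ethyl leaves the number in this assay essentially in place, since both a 1.3-fold lower number from compound 3 to compound 4 (0.12 log units; within the scatter) and a 1.7-fold lower number from compound 1 to compound 4 (0.24 log units; within the scatter) stay within the scatter. This shows that the phenyl ring of compound 3 is not needed to keep cytotoxicity in this range, something the earlier swaps on a single aromatic carbon could not reveal because the ring was present in all of them. Only a 2.7-fold lower number from compound 2 to compound 4 (0.42 log units; beyond the scatter) passes beyond the scatter, and it is a modest step, while the data shown offer nothing that explains why the number holds once the ring is gone.

The compounds shown span only ethyl and benzyl at this position, so how a longer chain such as butyl, or a chain ending in an amine or a carboxylic acid, would read remains open. On these data alone, it is also open whether a plain hydrogen in place of the ethyl would keep the number in the same range, or whether any group here can move it far at all.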